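The compounds below may be only part of what the source reports. "The series", "measured", "known", "first", "only" and "open" are said of these compounds alone.

Of the compounds shown here, three that share one core have been tested in a functional assay on U-87MG ATCC cells for antiproliferative activity against U-87 MG (Homo sapiens), read by MTT assay, with a stated time of 72 h (a higher number here means a weaker inhibitor, a lower number a stronger inhibitor), and they differ only in the aryl group attached to an oxygen on an aromatic ring. Compound 1 `Cc1nn(C)c(Oc2ccc(F)cc2F)c1/C=N\CCCCCCOc1cc2oc(=O)cc(C)c2cc1Cl` carries a 2,4-difluorophenyl there. In this assay compound 1 gives only a limit, > 25000 nM, and not a number. Compound 2 `Cc1nn(C)c(Oc2ccc(F)c(F)c2)c1/C=N\CCCCCCOc1cc2oc(=O)cc(C)c2cc1Cl` carries a 3,4-difluorophenyl. In this assay compound 2 likewise reaches only the limit of > 25000 nM. For the measured compounds named here, compound 3 `Cc1nn(C)c(Oc2cccc(Cl)c2)c1/C=N\CCCCCCOc1cc2oc(=O)cc(C)c2cc1Cl` carries a 3-chlorophenyl and is the one compound with a number: in this assay compound 3 gives 8460 nM. The step of an at least 2.9-fold lower number from compound 1 to compound 3 (0.47 log units; beyond the scatter) and the step of an at least 2.9-fold lower number from compound 2 to compound 3 (0.47 log units; beyond the scatter) both show that swapping this aryl group can shift the result at least modestly, although both steps begin at a limit (the limit of > 25000 nM in this assay, at which 2 of the 3 values shown sit), so their full size is not readable. Compound 4 `Cc1nn(C)c(Oc2ccc(I)cc2)c1/C=N\CCCCCCOc1cc2oc(=O)cc(C)c2cc1Cl` has not yet been measured; it differs from compound 3 by 4-iodophenyl in place of 3-chlorophenyl on an oxygen on an aromatic ring. Going by the values given here, no measured pair carries an iodine or tests this particular exchange, so the direction of the step is unknown. The step from compound 3 to compound 4 is therefore expected to stay within the scatter, a 1.2-fold higher number from compound 3 to compound 4 (0.07 log units; within the scatter), with wide uncertainty. For compound 4 the estimate is 10000 nM, in a range from 3000 nM to 30000 nM.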

Compound 4, half-maximal inhibitory concentration: 16800 nM
Compound 4: middle estimate off by 1.7-fold (0.23 log units), on the low side, and the stated range covers the measured number.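

In this assay the exchange of 3-chlorophenyl for 4-iodophenyl gives a 2.0-fold higher number from compound 3 to compound 4 (0.30 log units; within the scatter) and so stays within the scatter: compound 3 and compound 4 cannot be told apart, although both the halogen and its place on the ring differ. Among the four compounds, the two aryl groups carrying a single chlorine or iodine give numbers, while the two difluorophenyl groups of compound 1 and compound 2 give only a limit: the limit of > 25000 nM in this assay, at which 2 of the 4 values shown sit. The steps to compound 4 from those limits (an at least 1.4-fold lower number from compound 2 to compound 4 (0.17 log units; that floor lies within the scatter) and an at least 1.4-fold lower number from compound 1 to compound 4 (0.17 log units; that floor lies within the scatter)) have floors that lie within the scatter, so even this contrast is not firmly shown for compound 4, unlike the clearer steps to compound 3.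

Going by these compounds, since halogen and ring place change together here, their separate contributions stay open, and 4-chlorophenyl or 3-iodophenyl would be the groups needed to pull them apart. Also open, on these data alone, is how this position responds to an unsubstituted phenyl, or to a ring carrying an amine or a carboxylic acid in place of a halogen.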